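Compound 3 and the ring change in compound 4

The source may report more compounds than this note shows. Statements on the series, on what has been measured and on what is new or still open speak of the compounds shown alone.

Values in a functional assay on cells (Mast cell, Rattus norvegicus, strain Wistar) for activation, read by fluorescence, with a stated time of 15 min (a lower number here means that less compound is needed, a higher number that more compound is needed for the effect), so far
Compound 1 `CCCCCCCCCCCCCCCCCC(=O)CCCCCOP(=O)(O)OC[C@H](N)C(=O)O` gives > 10000 nM
Compound 2 `CCCCCCCCCCCCCCCCCC(=O)OC[C@@H](COP(=O)(O)OC[C@H](N)C(=O)O)OC` gives 5000 nM
Compound 3 `CCCCCCCCCCCCCCCCCC(=O)OC[C@@H](O)COP(=O)(O)O[C@@H](C)[C@H](N)C(=O)O` gives 2000 nM

Compound 3 stands lowest at 2000 nM of the two true numbers in the set. Compound 2 lies nearest at 5000 nM and the gap between them is beyond the usual scatter. Compound 1 gives > 10000 nM as a limit of the assay and not as a number.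

Compound 4 `CCCCCCCCCCCCCCCCCC(=O)OC[C@@H](O)COP(=O)(O)O[C@@H]1CN[C@@H](C(=O)O)C1` has yet to be measured. The change from compound 3 (a group of 8 heavy atoms (5 carbon, 1 nitrogen, 2 oxygen; one five-membered non-aromatic ring with 1 hetero atom) in place of a group of 7 heavy atoms (4 carbon, 1 nitrogen, 2 oxygen; no ring), on an oxygen) puts a group with one five-membered non-aromatic ring with 1 hetero atom where compound 3 has a group with no ring, in both cases on an oxygen bonded to phosphorus.

Among the compounds with values here, no two measured compounds differ in one place alone, so the data give no direct size for such a change. Within the data shown here, the only guide is that compound 3 at 2000 nM holds the lowest number of the set, so a moderate rise in this assay is expected rather than a fall. The expected step (a 2.5-fold higher number from compound 3 to compound 4 (0.40 log units; beyond the scatter)) is a rise, and it is only an estimate. For compound 4 the estimated value is 5000 nM with an expected range from 1500 nM to 20000 nM and a real chance that only a limit comes back.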

Compound 4, half-maximal effective concentration: > 10000 nM
Compound 4: only a limit was reported; the forecaster's own chance of this, stated with the estimate: 35%; at least 2.0-fold (0.30 log units) between middle value and limit.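

In this assay, within the data shown here, the change on an oxygen bonded to phosphorus gives an at least 5.0-fold higher number from compound 3 to compound 4 (0.69 log units; beyond the scatter), the first step in the set that can be read at a single place. Compound 4 gives > 10000 nM, which is a limit of the assay and not a number. So placing the group with one five-membered non-aromatic ring with 1 hetero atom on this oxygen raises the number beyond the scatter, but the true size of the step remains unknown, since the reading stops at this limit: the limit of > 10000 nM in this assay, at which 2 of the 4 values shown sit.

The compounds shown leave open whether the rise belongs to the ring as such or would also follow from an open-chain group of the same size, and whether a six-membered non-aromatic ring with 1 hetero atom on this oxygen would give a readable number. They also do not tell whether a longer chain in the rest of the molecule would bring compound 4 back into the range that the assay can report.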